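The source may report more compounds than this note shows. Statements on the series, on what has been measured and on what is new or still open speak of the compounds shown alone.

Compound 1, `CCCCN(C)S(=O)(=O)NC(=O)Nc1c(C(C)C)cccc1C(C)C`, is a sulfamide-urea built on a shared aromatic core with a short chain on the sulfonamide nitrogen. In an assay on liver for inhibition of sterol O-acyltransferase 1 (Rattus norvegicus), using microsomes (a higher number here means a weaker inhibitor, a lower number a stronger inhibitor), compound 1 gives 2300 nM. Compound 2, `CCCCCCCCCCCCCCN(C)S(=O)(=O)NC(=O)Nc1c(C(C)C)cccc1C(C)C`, carries the same core but a much longer chain, and in this assay compound 2 gives 330 nM. Within the data shown here, the single measured step is a 7.0-fold lower number from compound 1 to compound 2 (0.84 log units; beyond the scatter), which comes from decyl in place of hydrogen on a saturated chain carbon, four bonds along the chain from a sulfonamide nitrogen. Among the two numbers available, compound 2 stands as the lower one, and its only neighbour, compound 1, sits a clear distance away from it.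

Compound 3, `CCCCCCCCCCCCCCCCCCN(C)S(=O)(=O)NC(=O)Nc1c(C(C)C)cccc1C(C)C`, extends that chain once more: butyl in place of hydrogen on a saturated chain carbon, ten or more bonds along the chain from a sulfonamide nitrogen. Among the measured compounds shown here, the only step that bears on this change is the one from compound 1 to compound 2, and it was only modest even though it added a far larger piece. A smaller addition placed so far out along the chain is therefore expected to give a smaller step again, if any beyond the scatter, in the direction of a lower number: a 1.5-fold lower number from compound 2 to compound 3 (0.18 log units; within the scatter). Compound 3 is estimated at 220 nM, within a range from 80 nM to 600 nM.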

Compound 3, half-maximal inhibitory concentration: 1900 nM
Compound 3: the middle estimate sits 8.6-fold (0.94 log units) below what was measured; measured number above the stated range.
By their numbers in this assay, from the lowest: compound 2; then compounds 3 and 1 (each within the scatter of the next).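

Lengthening the chain further does not extend the earlier gain: butyl at this far position reverses it, giving a 5.8-fold higher number from compound 2 to compound 3 (0.76 log units; beyond the scatter). A longer chain therefore did not simply mean a lower number here, and compound 3 goes against the trend that the first step alone suggested. In this assay compound 2 keeps the lowest number, while compound 1 at 2300 nM and compound 3 at 1900 nM lie within the scatter of each other, so the shortest and longest chains shown cannot be told apart, and no measurement shown here accounts for the rise in the number.

Among these compounds, with only three chain lengths in view, the compounds leave open where along the chain the number turns upward and how sharp that turn is, which methyl, ethyl or propyl in place of hydrogen at this same position could help to settle. They also leave open whether a chain of similar length ending in an amine or a carboxylic acid would behave as compound 2 or as compound 3 does.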